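Aromatic methyl on compound 3: expected outcome in cytotoxicity

The source may hold more compounds than are shown below. What is called first, only, known or untested is meant among the compounds shown, and "the series" means these compounds.

Compound 1, `CC[C@H](C)[C@H](NC(=O)c1cnc2ccccc2c1Cl)C(=O)OC`: in an ADME assay on CCRF-CEM cells (Homo sapiens) for cytotoxicity (on this read-out higher numbers stand for lower toxicity in this test and lower numbers for higher toxicity in this test), compound 1 gives 23.3 uM.
Compound 2, `COC(=O)[C@H](CC(C)C)NC(=O)c1cnc2ccccc2c1Cl`: compound 2 gives 49.1 uM.
Compound 3, `COC(=O)[C@@H](NC(=O)c1cnc2ccccc2c1Cl)[C@@H](C)O`: compound 3 reaches only a limit of the test, > 100 uM.

Compound 3 therefore stands at the upper boundary of the numbers shown; its result is a limit and not a number, (the limit of > 100 uM in this assay, at which 1 of the 3 values shown sits). Compound 4, `COC(=O)[C@@H](NC(=O)c1cnc2cc(C)ccc2c1Cl)[C@@H](C)O`, differs from compound 3 by methyl in place of hydrogen on an aromatic carbon. All three measured steps concern the saturated chain carbon bearing the side chain, not the aromatic part of the shared core: a 2.1-fold higher number from compound 1 to compound 2 (0.32 log units; beyond the scatter), an at least 4.2-fold higher number from compound 1 to compound 3 (0.63 log units; beyond the scatter), an at least 2.0-fold higher number from compound 2 to compound 3 (0.30 log units; that floor lies within the scatter). None of them bears directly on a change at an aromatic carbon, so they give no guide to the size or direction of this step. With compound 3 already at the limit, compound 4 is expected to stay close to it, a number no higher from compound 3 to compound 4 (the limit leaves the size open), with no step beyond the scatter expected. The estimate for compound 4 is 100 uM, with a range from 40 uM to 250 uM, and a fair chance that the test again reports only a limit.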

Compound 4, half-maximal toxic concentration: > 100 uM
Compound 4 ended at the assay's limit; the forecaster's own chance of this, stated with the estimate: 55%; the middle value lies on the limit itself.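

Compound 3 and compound 4 both end at a limit of the test rather than at a number, so no step between them can be read: the limit of > 100 uM in this assay, at which 2 of the 4 values shown sit.

The compounds shown leave open whether methyl in place of hydrogen on an aromatic carbon changes the half-maximal toxic concentration at all.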